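Exchanging the sulfanyl arm of compound 3 for an ethylpiperazine

The source may report more compounds than this note shows. Statements on the series, on what has been measured and on what is new or still open speak of the compounds shown alone.

In a functional assay on MCF7 cells (Homo sapiens) for cytotoxicity, read by MTT assay, with a stated time of 24 h, tested at 80 ug/mL (a higher number here means a stronger effect of the compound at the concentration tested, a lower number a weaker effect), three compounds have been measured:
Compound 1 `Cn1c(-c2ccc(NC(=O)CSc3nc4ccccc4o3)cc2)nc(-c2ccccc2)c1-c1ccccc1` gives 76.3%.
Compound 2 `Cc1ccc2oc(SCC(=O)Nc3ccc(-c4nc(-c5ccccc5)c(-c5ccccc5)n4C)cc3)nc2c1` gives 65.1%.
Compound 3 `Cn1ccnc1SCC(=O)Nc1ccc(-c2nc(-c3ccccc3)c(-c3ccccc3)n2C)cc1` gives 64%.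

Compound 3 stands lowest of the three numbers. Its nearest neighbour is compound 2, with a step of a number 1.1 percentage points lower from compound 2 to compound 3 (within the scatter), so the two cannot be told apart. Its furthest is compound 1, with a step of a number 12.3 percentage points lower from compound 1 to compound 3 (beyond the scatter). The other measured step, a number 11.2 percentage points lower from compound 1 to compound 2 (beyond the scatter), changes only a methyl on an aromatic carbon.

Compound 4 `CCN1CCN(CC(=O)Nc2ccc(-c3nc(-c4ccccc4)c(-c4ccccc4)n3C)cc2)CC1` differs from compound 3 in one place: 4-ethylpiperazin-1-yl in place of (1-methyl-1H-imidazol-2-yl)sulfanyl on a saturated chain carbon bound to a carbonyl carbon. Among the compounds with values here, none of the measured steps bears directly on this change; the two steps that touch the sulfur merely swap one ring bound to it for another, and both were modest in size. Within the data shown here, there is thus no measured precedent for removing the sulfanyl link itself. The estimate for compound 4 is accordingly cautious, a step of a number 9 percentage points lower from compound 3 to compound 4 (within the scatter) from compound 3, with a wide range. Compound 4 is expected to give 55%, between 35% and 75%.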

Compound 4, a percentage reported as activity, at one concentration (the size of the read-out at that concentration, not a potency): 46.3%
For compound 4 the middle estimate is 8.7 percentage points above the measured one; the measured number falls inside the stated range.
By their numbers in this assay, from the lowest: compound 4; then compounds 3 and 2 (each within the scatter of the next); then compound 1.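

In this assay, putting 4-ethylpiperazin-1-yl on the saturated chain carbon bound to a carbonyl carbon gives a number 17.7 percentage points lower from compound 3 to compound 4 (beyond the scatter) and a number 18.8 percentage points lower from compound 2 to compound 4 (beyond the scatter) and a number 30 percentage points lower from compound 1 to compound 4 (beyond the scatter) when it replaces each of the three sulfanyl groups. The earlier compounds shown here varied only the ring carried on the sulfur, whereas these steps show that the number also falls when the sulfur and its ring leave together, whichever of the three sulfanyl groups is replaced. Nothing available explains this fall.

Because the sulfur and the ring change in one exchange, the compounds shown do not separate the loss of the sulfur from the arrival of the piperazine. A 1,3-benzoxazol-2-yl group joined through an amine nitrogen, or a morpholine ring on the same carbon, would help to tell these apart.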